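The source may hold more compounds than are shown below. What is called first, only, known or untested is meant among the compounds shown, and "the series" means these compounds.

Measured compounds:
compound 1, `CCCc1cccc(C[C@H](O)/C=C/[C@H]2CCC(=S)N2CCCCCCC(=O)O)c1`, 0.4 nM
compound 2, `O=C(O)CCCSCCN1C(=O)SC[C@@H]1/C=C/[C@@H](O)Cc1ccccc1`, 0.65 nM
compound 3, `Cc1cccc(C[C@H](O)/C=C/[C@H]2CCC(=S)N2CCSCCCC(=O)O)c1`, 0.5 nM

All three were tested in an assay on CHO cells for displacement of a labelled ligand from prostaglandin E2 receptor EP4 subtype (Mus musculus), read by scintillation counting, with a stated time of 60 min; a higher number here means a weaker inhibitor, a lower number a stronger inhibitor. Compound 2 gives the highest of the three numbers, but its neighbours lie close: compound 3 gives 0.5 nM, a number that lies within the usual scatter of the value of compound 2, and compound 1 gives 0.4 nM, also within the scatter. On these numbers the three compounds cannot be told apart in this assay.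

Compound 4, `O=C(O)CCCSCCN1C(=O)SC[C@@H]1/C=C/[C@@H](O)Cc1cccc(C(F)(F)F)c1`, is the compound still to be measured. It keeps the whole core of compound 2 and differs from it in one place: trifluoromethyl in place of hydrogen on an aromatic carbon. For the measured compounds named here, no measured pair shows this same change, so its size is not known directly. Compound 1 and compound 3 both carry a group on the phenyl ring that compound 2 leaves bare, and their values in this assay stay within the scatter of compound 2; this is the nearest guide available.

The step from compound 2 to compound 4 in this assay is therefore expected to be small, a 1.3-fold lower number from compound 2 to compound 4 (0.11 log units; within the scatter), and not beyond the scatter. For compound 4 the expected value in this assay is 0.5 nM, with a range from 0.2 nM to 1.5 nM.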

Compound 4, inhibition constant: 0.97 nM
For compound 4 the middle estimate is 1.9-fold (0.29 log units) below the measured one, and the stated range covers the measured number.
By their numbers in this assay, from the lowest: compounds 1, 3, 2 and 4 (each within the scatter of the next, the first and the last beyond it).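

For the compounds shown here, this is the first pair that differs in one place only, and in this assay the step reads a 1.5-fold higher number from compound 2 to compound 4 (0.17 log units; within the scatter), which lies within the scatter. At this aromatic carbon, meta to a large group, trifluoromethyl with its 4 heavy atoms therefore cannot be told apart from hydrogen on the core of compound 2, so the change from phenyl to 3-(trifluoromethyl)phenyl leaves the number in the same sub-nanomolar range as the other compounds. Nothing available bears on why this substitution leaves the number within the scatter.

The compounds shown leave open how a methoxy group, a nitrile, a chlorine atom or an amine at this same aromatic carbon would read in this assay, and whether trifluoromethyl on a different carbon of the ring would read as this one does. Going by these compounds alone, they also leave open whether this single step would stay within the scatter on the other prostaglandin receptor subtypes, or on a core with a longer chain in place of the one carried by compound 2.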